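Swapping the hydrazone arm: what compound 3 might show

The source may hold more compounds than are shown below. What is called first, only, known or untested is meant among the compounds shown, and "the series" means these compounds.

Measured in a functional assay on UACC-62 cells (Homo sapiens) for cytotoxicity, read by sulforhodamine B assay; a higher number here means that more compound is tolerated, a lower number that less compound is tolerated:
compound 1, `CC1=CC[C@@H]([C@@](C)(O)CCCC(C)(C)NC(=S)NN)CC1`: > 100000 nM
compound 2, `CC1=CC[C@@H]([C@@](C)(O)CCCC(C)(C)NC(=S)N/N=C\c2cccc(Cl)c2)CC1`: 42700 nM

Compound 1 reaches only a limit in this assay, and the limit of > 100000 nM in this assay, at which 1 of the 2 values shown sits, marks that edge. Among the measured compounds shown here, compound 2 is the one compound with an actual number, and it stands at 42700 nM. For the measured compounds named here, the single measured change, an at least 2.3-fold lower number from compound 1 to compound 2 (0.36 log units; beyond the scatter), concerns attaching the arylidene arm to the hydrazine end of the chain.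

Compound 3, `CC1=CC[C@@H]([C@@](C)(O)CCCC(C)(C)NC(=S)N/N=C(/C)c2ccccc2)CC1`, differs from compound 2 by a group of 9 heavy atoms (8 carbon, 1 nitrogen; one six-membered aromatic ring of carbon only) in place of a group of 9 heavy atoms (7 carbon, 1 nitrogen, 1 chlorine; one six-membered aromatic ring of carbon only), on an amide-type nitrogen. Going by the values given here, no measured step covers this exchange: the step from compound 1 to compound 2 added the arm rather than altering it, and compound 3 keeps an arm of the same size on the same nitrogen. The expected step of a 1.2-fold higher number from compound 2 to compound 3 (0.07 log units; within the scatter) is therefore small and not beyond the scatter in this assay. Compound 3 is estimated at 50000 nM, with a range from 20000 nM to 120000 nM.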

Compound 3, concentration lethal to 50% of the cells: > 100000 nM
Compound 3 ended at the assay's limit (the forecaster's own chance of this, stated with the estimate: 25%); middle value at least 2.0-fold (0.30 log units) away from the limit.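

Arms of the same size on the amide-type nitrogen are not interchangeable in this assay. Exchanging the chlorine-bearing arm for the arm with 8 carbon atoms and no chlorine gives an at least 2.3-fold higher number from compound 2 to compound 3 (0.36 log units; beyond the scatter), so carrying an arm of this size on that nitrogen does not by itself lower the number. The step between compound 1 and compound 3 cannot be read, and in this assay compound 3 leaves only compound 2 with an actual number, the other two values being limits: the limit of > 100000 nM in this assay, at which 2 of the 3 values shown sit.

The exchange removes the chlorine and adds a carbon in one move, so the compounds shown do not separate the two changes. They also leave open how the arm would read with a bromine or a methoxy group on its aromatic ring.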